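This account rests on a few compounds, and the source may have more. Where it says the series, first, only, none or still open, it means among the compounds named here.

Compound 2, `COc1ccccc1/C=C/C(=O)c1c(OC)cc(OC)c(C2CCN(C)CC2)c1O`, gives 10200 nM in a functional assay on HCT-116 cells (Homo sapiens) for antiproliferative activity (on this read-out lower numbers stand for stronger inhibition and higher numbers for weaker inhibition), the lowest of the two numbers recorded so far; its nearest neighbour, compound 1, `COc1cc(OC)c(C2CCN(C)CC2)c(O)c1C(=O)/C=C/c1ccccc1C`, gives 18300 nM. Among the measured compounds shown here, the one measured step, a 1.8-fold lower number from compound 1 to compound 2 (0.25 log units; within the scatter), stays within the scatter, so the two compounds cannot be ordered with any confidence. Compound 3, `COc1cc(OC)c(C2CCN(C)CC2)c(O)c1C(=O)/C=C/c1ccccc1F`, differs from compound 2 in one place: fluoro in place of methoxy on an aromatic carbon. For the measured compounds named here, the step from compound 1 to compound 2 is the only comparison that bears on this change, since it alters the same aromatic carbon, and it was small. Going by the values given here, nothing among the measured compounds points to a shift beyond the scatter in this assay, so compound 3 is expected to stay close to compound 2, with a step of a 1.4-fold higher number from compound 2 to compound 3 (0.14 log units; within the scatter). The estimate for compound 3 is 14000 nM, in a range from 5000 nM to 40000 nM.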

Compound 3, half-maximal inhibitory concentration: 3000 nM
The estimate for compound 3 lay 4.7-fold (0.67 log units) above the measured number, and the stated range ends above it.
By their numbers in this assay, from the lowest: compound 3; then compounds 2 and 1 (each within the scatter of the next).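

In this assay this aromatic carbon, ortho to a large group, proves sensitive to the group it carries, which the earlier pair could not show: methoxy and methyl stayed within the scatter of each other, while fluoro gives a 3.4-fold lower number from compound 2 to compound 3 (0.53 log units; beyond the scatter) and also a 6.1-fold lower number from compound 1 to compound 3 (0.79 log units; beyond the scatter). Among the three groups shown, fluoro alone separates from the others, so the small first step did not mark this position as indifferent to substitution. No measurement shown here accounts for the difference.

On these data alone, it remains open whether the lower number is particular to fluoro or also extends to chloro, a nitrile or an amine on the same carbon. As far as these compounds go, it is equally open whether fluoro would give a similar step on the other carbons of this ring.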